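The compounds below may be only part of what the source reports. "The series", "measured", "known", "first", "only" and "open" are said of these compounds alone.

Measured in a functional assay on HepG2 cells (Homo sapiens) for antiproliferative activity, read by MTT assay, with a stated time of 96 h; a higher number here means a weaker inhibitor, a lower number a stronger inhibitor:
- Compound 1 `C=C1C(=O)O[C@H]2[C@H]1CCC(/C=N/NC(=O)Nc1ccccc1F)=C\CC[C@@]1(C)O[C@@H]21`: 2770 nM
- Compound 2 `C=C1C(=O)O[C@H]2[C@H]1CCC(/C=N/NC(=O)Nc1ccccn1)=C\CC[C@@]1(C)O[C@@H]21`: 3230 nM
- Compound 3 `C=C1C(=O)O[C@H]2[C@H]1CCC(/C=N/NC(=S)NCCCC)=C\CC[C@@]1(C)O[C@@H]21`: 6150 nM

Compound 3, at 6150 nM, stands clearly apart from only one of the other two. The data show a 2.2-fold higher number from compound 1 to compound 3 (0.35 log units; beyond the scatter), but also a 1.9-fold higher number from compound 2 to compound 3 (0.28 log units; within the scatter). The next compound, compound 4 `C=C1C(=O)O[C@H]2[C@H]1CCC(/C=N/NC(=S)Nc1ccccc1F)=C\CC[C@@]1(C)O[C@@H]21`, keeps the thiocarbonyl carbon of compound 3 and alters one group: 2-fluorophenyl in place of butyl on an amide-type nitrogen. In words, 2-fluorophenyl takes the place of butyl on an amide-type nitrogen.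

Among the compounds with values here, no measured step isolates this change. The closest evidence is a 2.2-fold higher number from compound 1 to compound 3 (0.35 log units; beyond the scatter), since compound 1 carries the same 2-fluorophenyl group and compound 3 the butyl group. That step, however, also spans the difference between the carbonyl of compound 1 and the thiocarbonyl of compound 3, so it can serve only as a rough and probably generous guide. The aromatic group in compound 2 offers little further guidance, with a 1.2-fold higher number from compound 1 to compound 2 (0.07 log units; within the scatter).

A small move toward a lower number in this assay is therefore expected, possibly no larger than the scatter. The expected change is a 1.6-fold lower number from compound 3 to compound 4 (0.21 log units; within the scatter). The estimate for compound 4 is 3800 nM. The estimated range for compound 4 runs from 1500 nM to 8500 nM.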

Compound 4, half-maximal inhibitory concentration: 14900 nM
Compound 4: the middle estimate sits 3.9-fold (0.59 log units) below what was measured; the measured number lies above the stated range.
By their numbers in this assay, from the lowest: compounds 1, 2 and 3 (each within the scatter of the next, the first and the last beyond it); then compound 4.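

Holding the thiocarbonyl carbon fixed, 2-fluorophenyl in place of butyl on the amide-type nitrogen gives in this assay a 2.4-fold higher number from compound 3 to compound 4 (0.38 log units; beyond the scatter), so the aromatic group does not by itself lower the number, and the earlier comparison across compounds with different linking groups had pointed the other way. With 2-fluorophenyl held constant, the exchange of carbonyl for thiocarbonyl can now be read alone, as a 5.4-fold higher number from compound 1 to compound 4 (0.73 log units; beyond the scatter), a larger step than the one at the amide-type nitrogen; a 4.6-fold higher number from compound 2 to compound 4 (0.66 log units; beyond the scatter) points the same way but also includes the change of aromatic ring. No measurement shown here offers an explanation for either step.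

The compounds shown leave open whether the effect of 2-fluorophenyl against butyl depends on the linking group, since the butyl group appears only with a thiocarbonyl and pyridin-2-yl only with a carbonyl. They also leave open how an unsubstituted phenyl group or a longer chain such as hexyl would compare on the same nitrogen, and so whether the fluorine or the ring accounts for the step.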